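The source may hold more compounds than are shown below. What is called first, only, known or untested is meant among the compounds shown, and "the series" means these compounds.

Four compounds built on a shared core are compared in a functional assay on HeLa S3 cells (Homo sapiens) for antiproliferative activity, read by XTT assay, with a stated time of 72 h; on this read-out higher numbers stand for weaker inhibition and lower numbers for stronger inhibition. Compound 1, with the structure `COc1ncnc2c1c(-c1ccsc1)cn2[C@@H]1O[C@H](CO)[C@@H](O)[C@H]1O`, gives 3350 nM in this assay. Compound 2, drawn as `Cc1ncnc2c1c(I)cn2[C@@H]1O[C@H](CO)[C@@H](O)[C@H]1O`, gives 4080 nM in this assay. Of the two numbers shown, compound 2 holds the higher one, but its nearest neighbour is compound 1, and the gap between them lies within the usual scatter of repeated measurements, so the two cannot be placed in any order of potency. Compound 3, with the structure `Cc1nc(N)c2c(-c3ccco3)cn([C@@H]3O[C@H](CO)[C@@H](O)[C@H]3O)c2n1`, does not yield a number in this assay; its result, > 20000 nM, is a limit of the assay, as stated by the limit of > 20000 nM in this assay, at which 1 of the 3 values shown sits.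

Compound 4, not yet measured, has the structure `Cc1ncnc2c1c(-c1ccoc1)cn2[C@@H]1O[C@H](CO)[C@@H](O)[C@H]1O`. It differs from compound 2 in a single place: furan-3-yl in place of iodo on an aromatic carbon. Among the compounds with values here, no pair of measured compounds that differ in only one place is available, so the size of this change cannot be read off from a neighbouring pair. The step expected here is a 1.0-fold lower number from compound 2 to compound 4 (0.01 log units; within the scatter), which stays within the scatter. Compound 4 is therefore expected to give about 4000 nM in this assay, with a likely range from 1300 nM to 13000 nM.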

Compound 4, half-maximal inhibitory concentration: > 20000 nM
Compound 4: only a limit was reported (the forecaster's own chance of this, stated with the estimate: 15%); middle value at least 5.0-fold (0.69 log units) away from the limit.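

Within the data shown here, this is the first step measured at this position, an aromatic carbon two ring bonds from the ring nitrogen, and it shows that the group placed there matters: in this assay, replacing iodo with furan-3-yl brings an at least 4.9-fold higher number from compound 2 to compound 4 (0.69 log units; beyond the scatter). In this assay compound 4 gives > 20000 nM, which is a limit of the assay and not a number. The step therefore marks only the smallest possible size of the change, and the true gap may be larger, since compound 4 reaches the end of the measurable range shared with one other compound: the limit of > 20000 nM in this assay, at which 2 of the 4 values shown sit.

A single step cannot show whether the weaker inhibition follows from the five-membered aromatic ring as a whole, from its oxygen, or from the larger number of heavy atoms that enter in place of the iodine. A phenyl ring, a furan-2-yl group, or a small amine or chlorine at this same carbon on the core of compound 2 would help separate these possibilities.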